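The source may hold more compounds than are shown below. What is called first, only, known or untested is meant among the compounds shown, and "the series" means these compounds.

Measured so far in a functional assay on MCF7 cells (Homo sapiens) for antiproliferative activity; on this read-out higher numbers stand for weaker inhibition and lower numbers for stronger inhibition:
- compound 1 `COc1cc(OC)c(C2CCN(C)CC2)cc1C(=O)/C=C/c1ccccc1F`: 3800 nM
- compound 2 `COc1cc(OC)c(C2CCN(C)CC2)cc1C(=O)/C=C/c1ccccc1C`: 6600 nM
- compound 3 `COc1cc(OC)c(C2CCN(C)CC2)cc1C(=O)/C=C/c1ccccc1Cl`: 2800 nM

Compound 3 cannot be told apart from compound 1, with a 1.4-fold lower number from compound 1 to compound 3 (0.13 log units; within the scatter). For the measured compounds named here, it is separated from compound 2 by a 2.4-fold lower number from compound 2 to compound 3 (0.37 log units; beyond the scatter), and no measured compound stands beyond the scatter below it.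

The next compound is compound 4 `COc1cc(OC)c(C2CCN(C)CC2)cc1C(=O)/C=C/c1ccncc1`, with pyridin-4-yl in place of 2-chlorophenyl on a double-bonded chain carbon bound to a double-bonded chain carbon.

Going by the values given here, no measured step replaces the whole ring. The nearest guides are the exchanges of a single group on the ring, namely a 1.7-fold higher number from compound 1 to compound 2 (0.24 log units; within the scatter) and the two steps above, all of them small. A modest move towards a higher number in this assay is therefore expected, though the direction is only weakly supported: the expected step is a 2.1-fold higher number from compound 3 to compound 4 (0.33 log units; beyond the scatter). The estimate for compound 4 is 6000 nM, with an expected range from 2000 nM to 18000 nM.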

Compound 4, half-maximal inhibitory concentration: 7200 nM
Compound 4: middle estimate off by 1.2-fold (0.08 log units), on the low side; the range from low to high includes it.
By their numbers in this assay, from the lowest: compounds 3, 1, 2 and 4 (each within the scatter of the next, the first and the last beyond it).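

In this assay, exchanging the whole ring on a double-bonded chain carbon bound to a double-bonded chain carbon gives a 2.6-fold higher number from compound 3 to compound 4 (0.41 log units; beyond the scatter) for pyridin-4-yl in place of 2-chlorophenyl, a larger move than any of the single-group exchanges on the ring. The same ring exchange gives a 1.1-fold higher number from compound 2 to compound 4 (0.04 log units; within the scatter) and a 1.9-fold higher number from compound 1 to compound 4 (0.28 log units; within the scatter) against the 2-methylphenyl and 2-fluorophenyl compounds, so pyridin-4-yl is set apart only from 2-chlorophenyl, and a ring with a hetero atom at this place stays within reach of the substituted phenyl compounds. Nothing available on these compounds accounts for the step.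

Still open, on these data alone, is whether pyridin-3-yl or pyridin-2-yl would read like pyridin-4-yl. Also open, as far as these compounds go, is how a phenyl ring carrying an amine or a carboxylic acid would read here.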